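The source may report more compounds than this note shows. Statements on the series, on what has been measured and on what is new or still open speak of the compounds shown alone.

Compound 1 `O=C(O)/C(S)=C/c1c[nH]c2ccc(F)cc12` gives 930 nM in an assay on isolated protein for inhibition of Calpain-1 catalytic subunit (Sus scrofa); a lower number here means a stronger inhibitor, a higher number a weaker inhibitor. That is the highest of the three numbers recorded so far. Compound 3 `O=C(O)/C(S)=C/c1c[nH]c2cc(I)ccc12`, the nearest of the others, gives 300 nM in this assay, a gap beyond the scatter. Compound 2 `O=C(O)/C(S)=C/c1c[nH]c2c(F)cccc12` gives 110 nM in this assay and lies furthest from compound 1, again beyond the scatter.

Compound 4 `O=C(O)/C(S)=C/c1c[nH]c2ccc(I)cc12` has not yet been measured in this assay. It differs from compound 1 in one place: iodo in place of fluoro on an aromatic carbon. Among the measured compounds shown here, no measured pair shows this exact exchange at this position, so the size of the step can only be inferred loosely. Compound 3 carries iodo on the core and gives 300 nM, a lower number than compound 1, but its halogen sits at a different place, and compound 2 with fluoro at yet another place gives 110 nM, so neither settles the matter. The expectation is a modest move towards a lower number, a step of a 2.3-fold lower number from compound 1 to compound 4 (0.37 log units; beyond the scatter), not far beyond the scatter. For compound 4 the estimate in this assay is 400 nM, with a range from 150 nM to 1200 nM.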

Compound 4, half-maximal inhibitory concentration: 90 nM
Compound 4: middle estimate off by 4.4-fold (0.65 log units), on the high side; measured number outside the range, below it.
By their numbers in this assay, from the lowest: compounds 4 and 2 (each within the scatter of the next); then compound 3; then compound 1.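

In this assay, among the compounds shown here, iodo in place of fluoro on this aromatic carbon of the shared core brings a 10-fold lower number from compound 1 to compound 4 (1.01 log units; beyond the scatter), a large step and the only exchange in this set that can be read at a single place. For the compounds shown here, it shows that this position is sensitive to which halogen it carries, something the earlier compounds could not show, as their halogens sit at other places and no pair among them isolated one exchange. The data offer no measurement that accounts for the size of this step.

The compounds shown leave open whether chloro or bromo at this place would fall between fluoro and iodo, and whether a group that is not a halogen, such as methyl, methoxy or nitrile, would give a number close to that of iodo or of fluoro. They also leave open whether iodo in place of fluoro would bring a step of similar size at the other places on the ring, as the one step shown covers a single position.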